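This account rests on a few compounds, and the source may have more. Where it says the series, first, only, none or still open, it means among the compounds named here.

In a functional assay on cells for agonist activity at Glucose-dependent insulinotropic receptor (Homo sapiens), read by HTRF and cAMP accumulation, with a stated time of 30 min (a lower number here means that less compound is needed, a higher number that more compound is needed for the effect), compound 1 `CC(C)(C)OC(=O)N1CCC2(CC1)CC(CCCOc1ccc(S(C)(=O)=O)cc1)C2` gives 14 nM, compound 2 `CC(C)OC(=O)N1CCC2(CC1)CC(CCCOc1ccc(S(C)(=O)=O)c(F)c1)C2` gives 18 nM, and compound 3 `CS(=O)(=O)c1ccc(OCCCC2CC3(CCN(C(=O)OC4CCCC4)CC3)C2)cc1F` gives 23 nM. Going by the values given here, compound 3 stands within the scatter of both others: against compound 2, the only step measured, a 1.3-fold higher number from compound 2 to compound 3 (0.11 log units; within the scatter). Compound 4 `CCc1cnc(N2CCC3(CC2)CC(CCCOc2ccc(S(C)(=O)=O)c(F)c2)C3)nc1` differs from compound 3 in that (5-ethylpyrimidin-2-yl in place of cyclopentyloxycarbonyl on an amine nitrogen in a ring). Among the compounds with values here, no measured step changes this part of the shared core in such a way; the steps seen only swap one alkyl for another on the oxygen of the carbamate and stay inside the scatter. Compound 4 is therefore expected near its parent, with a 1.2-fold lower number from compound 3 to compound 4 (0.06 log units; within the scatter) in this assay, the estimate for compound 4 being 20 nM, ranging from 6 nM to 80 nM.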

Compound 4, half-maximal effective concentration: 123 nM
Beside the measured number, compound 4's estimate is 6.2-fold (0.79 log units) below it, and the stated range ends below it.
By their numbers in this assay, from the lowest: compounds 1, 2 and 3 (each within the scatter of the next); then compound 4.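

In this assay, going by these compounds alone, this amine nitrogen is the first place where a change goes beyond the scatter: a 5.3-fold higher number from compound 3 to compound 4 (0.73 log units; beyond the scatter), and a 6.8-fold higher number from compound 2 to compound 4 (0.83 log units; beyond the scatter). The earlier step only swapped one alkyl group on the carbamate oxygen, whereas here 5-ethylpyrimidin-2-yl replaces the whole carbamate, and matching cyclopentyloxycarbonyl in heavy atoms and hydrogen-bond acceptors does not keep the number. No measurement at hand accounts for this rise. The compounds shown leave open whether the step follows the aromatic ring or its ethyl group, as a plain pyrimidin-2-yl or a 5-methylpyrimidin-2-yl could tell.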